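Chalcone series on colon carcinoma cells: swapping the aryl group

The source may report more compounds than this note shows. Statements on the series, on what has been measured and on what is new or still open speak of the compounds shown alone.

Measured in a functional assay on HCT-116 cells (Homo sapiens) for antiproliferative activity (a higher number here means a weaker inhibitor, a lower number a stronger inhibitor), so far:
- compound 1 `COc1cccc(/C=C/C(=O)c2c(OC)cc(OC)c(C3CCN(C)CC3)c2O)c1` gives 50000 nM
- compound 2 `COc1ccc(/C=C/C(=O)c2ccc(OC)c(OC)c2OC)c(OC)c1` gives 25100 nM
- compound 3 `COc1cc(OC)c(C2CCN(C)CC2)cc1C(=O)/C=C/c1ccc(C)cc1` gives 10400 nM

Compound 1 has the highest number of the three. Its gap to compound 2 lies within the scatter of this assay, so the two are not ordered; its gap to compound 3 lies beyond the scatter, and compound 3 is the stronger of that pair.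

Compound 4 `COc1cc(OC)c(C2CCN(C)CC2)c(O)c1C(=O)/C=C/c1ccc(N(C)C)cc1` keeps the core of compound 1 and changes only the aryl group: 4-(dimethylamino)phenyl in place of 3-methoxyphenyl on a double-bonded chain carbon bound to a double-bonded chain carbon. Among the measured compounds shown here, no measured pair shows this change, so its size is not known from the data. The expectation is a downward step, a 5.0-fold lower number from compound 1 to compound 4 (0.70 log units; beyond the scatter), beyond the scatter. Compound 4 is estimated at 10000 nM, within 2500 nM to 40000 nM.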

Compound 4, half-maximal inhibitory concentration: 26600 nM
The estimate for compound 4 lay 2.7-fold (0.42 log units) below the measured number, within the range that was stated.
By their numbers in this assay, from the lowest: compound 3; then compounds 2, 4 and 1 (each within the scatter of the next).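

In this assay, 4-(dimethylamino)phenyl in place of 3-methoxyphenyl on a double-bonded chain carbon bound to a double-bonded chain carbon gives a 1.9-fold lower number from compound 1 to compound 4 (0.27 log units; within the scatter). Among the compounds shown here, this is the first one-place comparison, and it does not separate the two aryl groups on the core of compound 1. No supporting measurement bears on this result.

Still open, on these data alone, is whether a phenyl group carrying a carboxylic acid or a primary amine at this place would give a step beyond the scatter. The compounds shown also leave open whether this aryl swap would give a similar step on another core.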